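Methylating a Linker Amide in an Adenosine Receptor Series

A few compounds are considered here, and "the series" means these few. Any claim that something is new, unique, unknown or untested is made for them only; others in the source may bear on it.

Of the compounds shown here, two that share one core have been measured in an assay on HeLa cells for displacement of a labelled ligand from adenosine receptor A3 (Homo sapiens), read by fluorescence polarization, with a stated time of 30 min; a higher number here means a weaker inhibitor, a lower number a stronger inhibitor. Compound 1 `COc1ccc(-c2cc(NC(=O)CCC(=O)NCC(=O)NC3CCCCC3)nc(-c3ccc(OC)cc3)n2)cc1` gives 35100 nM in this assay. Compound 2 `COc1ccc(-c2cc(NC(=O)CCC(=O)NCC(=O)NCc3ccccc3)nc(-c3ccc(OC)cc3)n2)cc1` gives 26900 nM in this assay. The step from compound 1 to compound 2 is a 1.3-fold lower number from compound 1 to compound 2 (0.12 log units; within the scatter), which is a benzyl in place of cyclohexyl on an amide-type nitrogen. Compound 2 therefore gives the lower of the two numbers, but the two values sit within the scatter of each other, so no order between them can be claimed.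

Compound 3 `COc1ccc(-c2cc(NC(=O)CCC(=O)N(C)CC(=O)NCc3ccccc3)nc(-c3ccc(OC)cc3)n2)cc1` has not yet been measured in this assay. It differs from compound 2 by methyl in place of hydrogen on an amide-type nitrogen. Among the measured compounds shown here, no measured step in this set touches that position, so the only guide is that the one measured change in the linker region stayed within the scatter.

Compound 3 is therefore expected to give a value close to that of compound 2, with an expected step of a 1.0-fold higher number from compound 2 to compound 3 (0.02 log units; within the scatter). The estimate for compound 3 in this assay is 28000 nM, expected to fall between 10000 nM and 80000 nM.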

Compound 3, inhibition constant: 9500 nM
For compound 3 the middle estimate is 2.9-fold (0.47 log units) above the measured one, and the stated range ends above it.
By their numbers in this assay, from the lowest: compound 3; then compounds 2 and 1 (each within the scatter of the next).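

The amide-type nitrogen whose other neighbours are a carbonyl carbon and a saturated chain carbon does respond in this assay when a methyl replaces the amide hydrogen. Among the compounds shown here, this change gives a 2.8-fold lower number from compound 2 to compound 3 (0.45 log units; beyond the scatter), the only step in the set that lies beyond the scatter, although it is a modest one. For the compounds shown here, the earlier pair changed benzyl for cyclohexyl on another amide-type nitrogen and allowed no order to be claimed, so this single added carbon, with no ring and no net charge, is the first sign that the linker region is not indifferent to every change, though nothing available here accounts for the shift.

As far as these compounds go, whether an ethyl or a longer chain on the same nitrogen would lower the number further remains open, as does the outcome of a methyl on the other amide-type nitrogens. It is also open whether the same methyl would have a similar effect with cyclohexyl in place of benzyl, as the compounds shown test it only with the benzyl amide.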